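Replacing a Nitro Group Across Two Related Cores

The source may report more compounds than this note shows. Statements on the series, on what has been measured and on what is new or still open speak of the compounds shown alone.

Compound 1 `COc1ccc(/C=C(\C)C(=O)/C=C/c2ccc([N+](=O)[O-])cc2)cc1` is tested in an ADME assay on J774.A1 cells (Mus musculus) for cytotoxicity, read by MTT assay, with a stated time of 48 h (on this read-out higher numbers stand for lower toxicity in this test and lower numbers for higher toxicity in this test), and gives 30000 nM. Compound 2 `COc1ccc(/C=C(\C)C(=O)/C=C/c2ccc(N(C)C)cc2)cc1` differs from compound 1 in one place, (dimethylamino in place of nitro on an aromatic carbon), and in this assay compound 2 gives 36200 nM; the step is a 1.2-fold higher number from compound 1 to compound 2 (0.08 log units; within the scatter). Compound 3 `COc1ccc(/C=C/C(=O)/C(C)=C/c2ccc([N+](=O)[O-])cc2)cc1` is built from the same atoms as compound 1, joined differently; the difference between the two cores is not broken down here. In this assay compound 3 gives 36600 nM. Compound 4 `COc1ccc(/C=C/C(=O)/C(C)=C/c2ccc(N(C)C)cc2)cc1` carries the same change on the core of compound 3: dimethylamino in place of nitro on an aromatic carbon. Because the earlier step of a 1.2-fold higher number from compound 1 to compound 2 (0.08 log units; within the scatter) was small, a step of similar size is expected this time, a 1.1-fold higher number from compound 3 to compound 4 (0.04 log units; within the scatter). On that basis compound 4 is estimated at 40000 nM in this assay, most likely between 20000 nM and 80000 nM.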

Compound 4, half-maximal cytotoxic concentration: 34300 nM
Compound 4: the middle estimate sits 1.2-fold (0.07 log units) above what was measured; low and high end bracket the measured number.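

In this assay, the swap of nitro for dimethylamino on the second core gives a 1.1-fold lower number from compound 3 to compound 4 (0.03 log units; within the scatter). Set side by side, the two cores show no difference in how this change plays out: the same change on two cores in this assay, a 1.2-fold higher number (0.08 log units; within the scatter) from compound 1 to compound 2 and a 1.1-fold lower number (0.03 log units; within the scatter) from compound 3 to compound 4, 1.3-fold (0.11 log units) apart, within the scatter of two such steps. Going by these compounds alone, this shows only that the swap leaves the number within the scatter on both cores; with no visible effect on either, it does not show that a change large enough to move the number would carry over from one core to the other in the same way.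

The compounds shown leave open whether a carboxylic acid or an unsubstituted amine on that aromatic carbon would shift the number beyond the scatter. From the compounds shown here alone, whether either core would then respond like the other also remains open.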